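Fluoro to methoxy on the anilide of compound 2

The source may hold more compounds than are shown below. What is called first, only, known or untested is meant among the compounds shown, and "the series" means these compounds.

Measured so far:
Compound 1, `CSc1ccc2c(c1)c(O)c(C(=O)N(C)c1ccccn1)c(=O)n2C`: 65%
Compound 2, `CSc1ccc2c(c1)c(O)c(C(=O)N(C)c1ccc(F)cc1)c(=O)n2C`: 100%

In a functional assay on the whole organism for inhibition, with Mus musculus as the target, at a dose of 32 mg/kg by the oral route (a lower number here means less inhibition, a higher number more inhibition at the dose given (going by the name of the read-out)), compound 2 gives 100%, the highest of the two numbers at hand. Going by the values given here, its only neighbour, compound 1, gives 65% in this assay, and the step of a number 35 percentage points higher from compound 1 to compound 2 (beyond the scatter) is the sole measured step available. The next compound, compound 3 with the structure `COc1ccc(N(C)C(=O)c2c(O)c3cc(SC)ccc3n(C)c2=O)cc1`, keeps the whole of compound 2 except for one change: methoxy in place of fluoro on an aromatic carbon. Among the compounds with values here, this difference is not the one behind the measured step, which swapped the whole ring on the amide nitrogen rather than a single group on it, so that step gives only a rough sense of how much this assay can move. Compound 2 already gives the highest number at hand in this assay, and a small change at the far end of the anilide would be expected to leave the number near that level, with some room to fall back. For compound 3 a step of a number 15 percentage points lower from compound 2 to compound 3 (beyond the scatter) is therefore expected, and the estimated read-out for compound 3 in this assay is 85%, within the range 55% to 100%.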

Compound 3, a percentage reported as inhibition, in the whole organism at one dose (the size of the read-out at that dose, not a potency): 100%
The estimate for compound 3 lay 15 percentage points below the measured number; the range from low to high includes it.
By their numbers in this assay, from the lowest: compound 1; then compounds 2 and 3 (each within the scatter of the next).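

In this assay the swap of fluoro for methoxy, on an aromatic carbon para to a large group, gives no change at the digits printed from compound 2 to compound 3 (within the scatter) and so shows that this place on the anilide accepts two heavy atoms and a hydrogen-bond acceptor in place of a single fluorine without a difference the read-out can resolve at this dose. The second step, a number 35 percentage points higher from compound 1 to compound 3 (beyond the scatter) when 4-methoxyphenyl replaces pyridin-2-yl on the amide nitrogen, has the same printed size as a number 35 percentage points higher from compound 1 to compound 2 (beyond the scatter) and shows that the higher number over compound 1 does not depend on fluoro alone, since both 4-substituted phenyl compounds share it. No measurement at hand bears on why these groups give this result.

On these data alone, compound 2 and compound 3 stand level in a read-out taken at one dose, which is not a potency, so whether the two would separate at a lower dose stays open. As far as these compounds go, it also stays open what an amine, a carboxylic acid or a longer chain such as butoxy would give at this place on the phenyl ring.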